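Cytotoxicity Series: Ester in Place of Primary Amide

The source may hold more compounds than are shown below. What is called first, only, known or untested is meant among the compounds shown, and "the series" means these compounds.

Compound 1 `Cc1cc(C)c(Oc2cc(Nc3ccc(C#N)cc3)ncc2C(=O)NCc2cn(Cc3ccccc3[N+](=O)[O-])nn2)c(C)c1` carries 2-nitrophenyl on a saturated chain carbon bound to an aromatic nitrogen; in an ADME assay on MT4 cells (Homo sapiens) for cytotoxicity, read by MTT assay, with a stated time of 5 days (on this read-out lower numbers stand for higher toxicity in this test and higher numbers for lower toxicity in this test), compound 1 gives > 212000 nM, which is the limit of > 212000 nM in this assay, at which 1 of the 3 values shown sits. Compound 2 `Cc1ccc(Cn2cc(CNC(=O)c3cnc(Nc4ccc(C#N)cc4)cc3Oc3c(C)cc(C)cc3C)nn2)cc1`, with 4-methylphenyl at that carbon, gives 165000 nM in this assay. Compound 3 `Cc1cc(C)c(Oc2cc(Nc3ccc(C#N)cc3)ncc2C(=O)NCc2cn(CC(N)=O)nn2)c(C)c1`, with carbamoyl there, gives 24000 nM in this assay and stands lowest of the two numbers; the nearest is the step of a 6.9-fold lower number from compound 2 to compound 3 (0.84 log units; beyond the scatter), while an at least 8.8-fold lower number from compound 1 to compound 3 (0.94 log units; beyond the scatter) starts from a limit. Compound 4 `COC(=O)Cn1cc(CNC(=O)c2cnc(Nc3ccc(C#N)cc3)cc2Oc2c(C)cc(C)cc2C)nn1` differs from compound 3 by methoxy in place of amino on a carbonyl carbon. For the measured compounds named here, no measured step touches this carbonyl carbon; both measured steps exchange the whole group on the chain carbon. The expected step of a 1.5-fold higher number from compound 3 to compound 4 (0.16 log units; within the scatter) is therefore small. Compound 4 is estimated at 35000 nM, between 12000 nM and 110000 nM.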

Compound 4, half-maximal cytotoxic concentration: 13800 nM
Beside the measured number, compound 4's estimate is 2.5-fold (0.40 log units) above it; measured number inside the range.
By their numbers in this assay, from the lowest: compounds 4 and 3 (each within the scatter of the next); then compound 2. At a limit, above all of these: compound 1.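

In this assay, the carbonyl carbon tolerates methoxy for amino with a 1.7-fold lower number from compound 3 to compound 4 (0.24 log units; within the scatter), so the ester and the primary amide cannot be told apart here. Methoxycarbonyl, like carbamoyl, stands well apart from the aryl group of compound 2, with a 12-fold lower number from compound 2 to compound 4 (1.08 log units; beyond the scatter). The value of compound 1 is a limit and not a number, so an at least 15-fold lower number from compound 1 to compound 4 (1.18 log units; beyond the scatter) gives only a floor: the limit of > 212000 nM in this assay, at which 1 of the 4 values shown sits.

From the compounds shown here alone, whether a carboxylic acid on this carbonyl carbon would read like compound 3 and compound 4 remains open. So does the effect of a longer chain carrying the carbonyl group.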